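Swapping a Chlorophenyl for Furan on a Fused Core

A few compounds are considered here, and "the series" means these few. Any claim that something is new, unique, unknown or untested is made for them only; others in the source may bear on it.

Compound 2 `COc1cccc(-c2nc3c(-c4ccc(Cl)cc4)n[nH]c3c(=O)n2NC(=O)c2ccccc2)c1` has been measured in a functional assay on HT-29 cells (Homo sapiens) for cytotoxicity, read by sulforhodamine B assay, with a stated time of 2 days, tested at 100 uM (on this read-out higher numbers stand for more inhibition at the one concentration tested (going by the name of the read-out) and lower numbers for less inhibition), where compound 2 gives 87.3%. Among the measured compounds shown here, that is the higher of the two numbers known so far. Its only companion, compound 1 `CCCc1n[nH]c2c(=O)n(NC(=O)c3ccccc3)c(-c3cccc(OC)c3)nc12`, carries propyl where compound 2 carries 4-chlorophenyl; in this assay compound 1 gives 6.27%. The step of a number 81 percentage points higher from compound 1 to compound 2 (beyond the scatter) shows how much that single replacement mattered.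

Compound 3 `COc1cccc(-c2nc3c(-c4ccco4)n[nH]c3c(=O)n2NC(=O)c2ccccc2)c1` has not yet been measured. It departs from compound 2 in one place: furan-2-yl in place of 4-chlorophenyl on an aromatic carbon. For the measured compounds named here, only the step from compound 1 to compound 2 bears on this change, and it was large: an aromatic ring on that aromatic carbon, rather than a propyl chain, went with a far higher number. Compound 3 keeps an aromatic ring there, though a five-membered one with 1 hetero atom in place of the six-membered carbon ring. Because of the large step of a number 81 percentage points higher from compound 1 to compound 2 (beyond the scatter), and since compound 3 keeps an aromatic ring, the expected step is a number 32.3 percentage points lower from compound 2 to compound 3 (beyond the scatter), a moderate fall rather than a collapse. For compound 3 the estimate in this assay is therefore 55%, with a likely range from 15% to 90%.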

Compound 3, a percentage reported as inhibition, at one concentration (the size of the read-out at that concentration, not a potency): 49.8%
Compound 3: middle estimate off by 5.2 percentage points, on the high side; measured number inside the range.
By their numbers in this assay, from the lowest: compound 1; then compound 3; then compound 2.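

In this assay, replacing 4-chlorophenyl with furan-2-yl gives a number 37.5 percentage points lower from compound 2 to compound 3 (beyond the scatter), so keeping an aromatic ring on this aromatic carbon is not enough to preserve the full read-out, and the two rings are not interchangeable here. Yet replacing propyl with furan-2-yl gives a number 43.5 percentage points higher from compound 1 to compound 3 (beyond the scatter), so the five-membered ring still recovers a substantial part of what separates propyl from 4-chlorophenyl, and the three groups give three clearly separate levels at this one position. Nothing measured on these groups accounts for this order, so the data describe the ranking without explaining it.

The compounds shown leave open whether the high number of compound 2 goes with the chlorine atom or with the six-membered carbon ring, a question that a plain phenyl group on the same carbon would help to settle. They also leave open where a thiophene ring, a pyridine ring or a longer alkyl chain would fall relative to these three groups.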